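Swapping the sulfur-linked ring for a piperazine

The source may report more compounds than this note shows. Statements on the series, on what has been measured and on what is new or still open speak of the compounds shown alone.

Measured compounds and their values in a functional assay on HT-29 cells (Homo sapiens) for cytotoxicity, read by MTT assay, with a stated time of 24 h, tested at 0.64 ug/mL; a lower number here means a weaker effect, a higher number a stronger effect of the compound at the concentration tested:
compound 1 `Cn1c(-c2ccc(NC(=O)CSc3nc4ccccc4s3)cc2)nc(-c2ccccc2)c1-c1ccccc1`, 9.8%
compound 2 `Cn1nnnc1SCC(=O)Nc1ccc(-c2nc(-c3ccccc3)c(-c3ccccc3)n2C)cc1`, 38%
compound 3 `Cn1ccnc1SCC(=O)Nc1ccc(-c2nc(-c3ccccc3)c(-c3ccccc3)n2C)cc1`, 13.6%

Compound 3 sits second highest of the three numbers; its value and that of compound 1 lie within the scatter of each other, while compound 2 stands clearly higher, as the step of a number 24.4 percentage points lower from compound 2 to compound 3 (beyond the scatter) shows.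

The change to compound 4 `CCN1CCN(CC(=O)Nc2ccc(-c3nc(-c4ccccc4)c(-c4ccccc4)n3C)cc2)CC1` is 4-ethylpiperazin-1-yl in place of (1-methyl-1H-imidazol-2-yl)sulfanyl on a saturated chain carbon bound to a carbonyl carbon. The three measured steps all exchange one ring on the sulfur for another: a number 28.2 percentage points higher from compound 1 to compound 2 (beyond the scatter), a number 3.8 percentage points higher from compound 1 to compound 3 (within the scatter) and a number 24.4 percentage points lower from compound 2 to compound 3 (beyond the scatter). Within the data shown here, none of them removes the sulfur itself or brings in a saturated ring in its place, so no measured step bears directly on this change. What they do show is that varying this end of the molecule moves the read-out only modestly, and that two of the three compounds cluster at the low end. With nothing pointing one way, the step of a number 2.4 percentage points higher from compound 3 to compound 4 (within the scatter) is expected to be small, though a broad range must be allowed.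

Compound 4 is therefore estimated at 16% in this assay, with a likely range from 4% to 38%.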

Compound 4, a percentage reported as activity, at one concentration (the size of the read-out at that concentration, not a potency): 7.4%
For compound 4 the middle estimate is 8.6 percentage points above the measured one, and the stated range covers the measured number.
By their numbers in this assay, from the lowest: compounds 4, 1 and 3 (each within the scatter of the next); then compound 2.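

In this assay, the sulfur and its aromatic ring can give way to 4-ethylpiperazin-1-yl on the saturated chain carbon bound to a carbonyl carbon with only a number 6.2 percentage points lower from compound 3 to compound 4 (within the scatter) and a number 2.4 percentage points lower from compound 1 to compound 4 (within the scatter) as the outcome, so replacing the sulfur link with a saturated ring leaves the read-out level with those two compounds. Compound 2 alone stands apart, with a number 30.6 percentage points lower from compound 2 to compound 4 (beyond the scatter) in this comparison, which means that among these four compounds the higher number goes with (1-methyl-1H-tetrazol-5-yl)sulfanyl only, while compound 1 and compound 3 keep a sulfur and an aromatic ring yet sit with compound 4. No measurement at hand explains how this replacement acts.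

The compounds shown leave open whether a piperazine without the ethyl, a morpholine or an open-chain dimethylamino group would read any differently at this chain carbon. They also leave open whether a longer chain leading to the 4-ethylpiperazin-1-yl would change the read-out, and whether 1-methyl-1H-tetrazol-5-yl keeps its higher number without the sulfur.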